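Swapping a propylphenyl amide for an aminophenyl amide

This account rests on a few compounds, and the source may have more. Where it says the series, first, only, none or still open, it means among the compounds named here.

For the measured compounds named here, compound 1 `CCCc1ccc(C(=O)Nc2cccc(NC(=O)COc3ccc4c(=O)ccoc4c3)c2)cc1` carries the only measured number here: in an assay on isolated protein for inhibition of Rho-associated protein kinase 1 (Homo sapiens), read by scintillation counting, radiometric assay and 33P incorporation, with a stated time of 40 min, in the presence of a further agent that is not named here (on this read-out higher numbers stand for weaker inhibition and lower numbers for stronger inhibition), compound 1 gives 143 nM. Compound 2 `CC(C)(C)c1ccc(S(=O)(=O)Nc2cccc(NC(=O)COc3ccc4c(=O)ccoc4c3)c2)cc1` reaches only a limit in this assay, where compound 2 gives > 10000 nM, that is the limit of > 10000 nM in this assay, at which 1 of the 2 values shown sits. Compound 3 `Nc1cccc(C(=O)Nc2cccc(NC(=O)COc3ccc4c(=O)ccoc4c3)c2)c1` awaits measurement. It differs from compound 1 by 3-aminophenyl in place of 4-propylphenyl on a carbonyl carbon. Going by the values given here, no step between measured compounds is available to anchor this change, so its size is uncertain. The expected step is a 2.4-fold higher number from compound 1 to compound 3 (0.39 log units; beyond the scatter), a modest weakening slightly beyond the scatter. Compound 3 is estimated at 350 nM, with a range from 70 nM to 1800 nM.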

Compound 3, half-maximal inhibitory concentration: 670 nM
Beside the measured number, compound 3's estimate is 1.9-fold (0.28 log units) below it; the range from low to high includes it.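

In this assay, 3-aminophenyl in place of 4-propylphenyl on the carbonyl carbon brings a 4.7-fold higher number from compound 1 to compound 3 (0.67 log units; beyond the scatter), a modest weakening that still leaves a measurable number rather than a limit. The swap replaces the propyl chain with an amine and also moves the substituent on the ring, so this single step cannot separate those two changes. Nothing measured here gives a reason for the step.

Still open, from the compounds shown here alone, is how a 4-aminophenyl group, which would keep the substituent where the propyl chain sat, or a longer chain such as 4-butylphenyl, would compare with compound 1.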